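The source may hold more compounds than are shown below. What is called first, only, known or untested is meant among the compounds shown, and "the series" means these compounds.

Working notes on the series.

Compound 1 `COc1ccc(C2=NN(C3=NC(c4ccccc4)CS3)C(c3cccc4ccccc34)C2)cc1` carries a methoxy on its aryl ring and serves as the reference point. In a functional assay on HeLa cells (Homo sapiens) for inhibition, read by CCK-8 assay, with a stated time of 48 h (a lower number here means a stronger inhibitor, a higher number a weaker inhibitor), compound 1 gives 3310 nM. Among the measured compounds shown here, the only other measured member, compound 2 `O=C1CSC(N2N=C(c3ccc(Br)cc3)CC2c2ccc3ccccc3c2)=N1`, gives 4220 nM in this assay. The gap between these two numbers lies within the usual scatter, so neither compound can be set apart from the other on potency, and compound 1 stands merely as the one with the smaller of the two numbers, not as a stronger inhibitor.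

Compound 3 `Clc1ccc(C2=NN(C3=NC(c4ccccc4)CS3)C(c3cccc4ccccc34)C2)cc1` is the next member to be measured. It differs from compound 1 by chloro in place of methoxy on an aromatic carbon. For the measured compounds named here, no pair of measured compounds shows this kind of change, so there is no measured step to anchor an expectation. On the evidence available, a step of small size is expected, with no confident direction, and quite possibly none beyond the scatter. For compound 3 the estimated value in this assay is 3000 nM, with a range from 1200 nM to 7500 nM. This estimate corresponds to a step of a 1.1-fold lower number from compound 1 to compound 3 (0.04 log units; within the scatter), which is expected to sit close to the scatter of the measurement.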

Compound 3, half-maximal inhibitory concentration: 9940 nM
The estimate for compound 3 lay 3.3-fold (0.52 log units) below the measured number, outside the stated range (above it).
By their numbers in this assay, from the lowest: compounds 1 and 2 (each within the scatter of the next); then compound 3.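

In this assay, among the compounds shown here, the change from 4-methoxyphenyl to 4-chlorophenyl gives the first measured step, a 3.0-fold higher number from compound 1 to compound 3 (0.48 log units; beyond the scatter) and therefore beyond the scatter. This shows that the substituent on this aromatic carbon, para to a large group, is not indifferent on the core of compound 1: with the rest of the structure held fixed, chloro gives the weaker inhibitor and methoxy the stronger one. No measurement available bears on the reason for this difference.

A single pair cannot separate what is lost with methoxy from what is gained with chloro, and it cannot show how a fluoro group, an amine, a carboxylic acid or a longer chain such as ethoxy on the same carbon would read in this assay on this core. Going by these compounds, it also remains open whether the change from methoxy to chloro would give a step of similar size and direction on another core, such as that of compound 2.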